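This account rests on a few compounds, and the source may have more. Where it says the series, first, only, none or still open, it means among the compounds named here.

Of the compounds shown here, three built on one shared core have been measured in an assay on HT-29 cells with Methylated-DNA--protein-cysteine methyltransferase (Homo sapiens) as the target, with a stated time of 30 min; a higher number here means that more compound is needed for the effect, a lower number that less compound is needed. Compound 1 `Nc1nc(OCc2ccccc2)c2[nH]c(N)nc2n1` gives 0.7 uM. Compound 2 `Nc1nc(OCc2ccccc2)c2[nH]c(O)nc2n1` gives 0.3 uM in this assay, and compound 3 `Nc1nc(OCc2ccccc2)c2[nH]c(C(F)(F)F)nc2n1` gives 0.4 uM. The step of a 2.3-fold lower number from compound 1 to compound 2 (0.37 log units; beyond the scatter) is modest but beyond the scatter, whereas a 1.8-fold lower number from compound 1 to compound 3 (0.24 log units; within the scatter) and a 1.3-fold higher number from compound 2 to compound 3 (0.12 log units; within the scatter) both stay within it. Compound 2 thus stands at the lowest of the three numbers; compound 3 lies within the scatter of it, and only compound 1 sits clearly apart.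

Compound 4 `Oc1nc(OCc2ccccc2)c2[nH]c(O)nc2n1` has not yet been measured. It differs from compound 2 by hydroxy in place of amino on an aromatic carbon. Among the measured compounds shown here, the only measured step that bears on this is the one between compound 1 and compound 2, in which the same exchange at a different place in the core gave a 2.3-fold lower number from compound 1 to compound 2 (0.37 log units; beyond the scatter), a modest lowering. For the measured compounds named here, no measured pair shows this exchange at the place now concerned, so the size of the effect there is not known. A lowering of similar size, or no step beyond the scatter, is the expectation in this assay. Compound 4 is therefore estimated to give 0.2 uM, with a range from 0.08 uM to 0.6 uM. This estimate corresponds to an expected step of a 1.5-fold lower number from compound 2 to compound 4 (0.18 log units; within the scatter).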

Compound 4, concentration for half-maximal effect: 25 uM
Beside the measured number, compound 4's estimate is 130-fold (2.10 log units) below it; the measured number lies above the stated range.
By their numbers in this assay, from the lowest: compounds 2, 3 and 1 (each within the scatter of the next, the first and the last beyond it); then compound 4.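

At the aromatic carbon between two ring nitrogen atoms, hydroxy in place of amino has a far larger effect in this assay than anything seen earlier, with an 83-fold higher number from compound 2 to compound 4 (1.92 log units; beyond the scatter) as the result of a change of a single heavy atom. The same exchange at the other place on the shared core gave only a 2.3-fold lower number from compound 1 to compound 2 (0.37 log units; beyond the scatter) and so did not predict this outcome. In these two pairs, the same exchange gives steps of very different size at the two places. Compounds 1, 2 and 3 all keep amino at this place, so their narrow spread could not reveal how much the number depends on the group there, and nothing available explains why the step is so large.

With a single pair changing this place, the compounds shown leave open whether the number rises with the loss of amino or with the arrival of hydroxy, and whether a methylamino group, a methyl group or a plain hydrogen there would keep it low. They also leave open whether the step would be of similar size with amino or trifluoromethyl at the other place.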